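Estimating compound 4 from a thiophene limit

The source may hold more compounds than are shown below. What is called first, only, known or untested is meant among the compounds shown, and "the series" means these compounds.

Values in a functional assay on ECa-109 cells (Homo sapiens) for antiproliferative activity, read by MTT assay, with a stated time of 72 h; a higher number here means a weaker inhibitor, a lower number a stronger inhibitor:
- Compound 1 `C#CCSc1nc(N/N=C/c2cc(OC)c(OC)c(OC)c2)c2nnn(Cc3ccccc3)c2n1` gives 6540 nM
- Compound 2 `C#CCSc1nc(N/N=C/c2c(O)ccc3ccccc23)c2nnn(Cc3ccccc3)c2n1` gives 6520 nM
- Compound 3 `CCCSc1nc(N/N=C/c2cccs2)c2nnn(Cc3ccccc3)c2n1` gives > 64000 nM

Compound 3 gives > 64000 nM as a limit of the assay, not a number. From the compounds shown here alone, its exact place therefore stays unknown. Compound 4 `CCCSc1nc(N/N=C/c2ccccc2F)c2nnn(Cc3ccccc3)c2n1` has 2-fluorophenyl in place of thiophen-2-yl on a carbon with a double bond to nitrogen and awaits measurement. Going by the values given here, no measured pair shows this change alone. Compound 1 gives 6540 nM and compound 2 gives 6520 nM as true numbers, so a lower number in this assay is expected, though of uncertain size. The expected change is an at least 2.1-fold lower number from compound 3 to compound 4 (0.32 log units; beyond the scatter) in this direction. Compound 4 is estimated at 30000 nM within a range of 9000 nM to 64000 nM and may also return only a limit.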

Compound 4, half-maximal inhibitory concentration: > 64000 nM
Compound 4 was reported as a limit; the forecaster's own chance of this, stated with the estimate: 40%; middle value at least 2.1-fold (0.32 log units) from the limit.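

No step can be read from compound 3 to compound 4, because each gives only a limit, not a number: the limit of > 64000 nM in this assay, at which 2 of the 4 values shown sit.

Still open, from the compounds shown here alone, is how far each compound lies past that limit, and whether thiophen-2-yl or 2-fluorophenyl gives the stronger inhibitor.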